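This account rests on a few compounds, and the source may have more. Where it says the series, first, only, none or still open, it means among the compounds named here.

Measured in a functional assay on HeLa cells (Homo sapiens) for inhibition, read by sulforhodamine B assay; on this read-out lower numbers stand for stronger inhibition and higher numbers for weaker inhibition:
- compound 1 `Cc1ccc(NC2=CC(=O)c3nc4n(c3C2=O)[C@H]2OC[C@@H](O)[C@H]2OC4)cc1`: 3860 nM
- compound 2 `O=C1C=C(Nc2ccccc2)C(=O)c2c1nc1n2[C@H]2OC[C@@H](O)[C@H]2OC1`: 5620 nM
- compound 3 `O=C1C=C(N2CCCCC2)C(=O)c2c1nc1n2[C@H]2OC[C@@H](O)[C@H]2OC1`: > 16000 nM, a limit and not a number

Compound 3 has no number, only (the limit of > 16000 nM in this assay, at which 1 of the 3 values shown sits). Compound 4 `O=C1C=C(N2CCCC2)C(=O)c2c1nc1n2[C@H]2OC[C@@H](O)[C@H]2OC1` carries pyrrolidin-1-yl in place of piperidin-1-yl on a double-bonded ring carbon. Among the compounds with values here, no measured step makes this exchange. The nearest steps change the same carbon: an at least 4.1-fold higher number from compound 1 to compound 3 (0.61 log units; beyond the scatter) and an at least 2.8-fold higher number from compound 2 to compound 3 (0.45 log units; beyond the scatter). Both bring in piperidin-1-yl in place of an aromatic amino group, whereas here both groups are non-aromatic rings. No step beyond the scatter is therefore expected in this assay, and the expected step is a number no higher from compound 3 to compound 4 (the limit leaves the size open). For compound 4 the estimate is 16000 nM, with an expected range of 7000 nM to 36000 nM.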

Compound 4, half-maximal inhibitory concentration: > 16000 nM
Compound 4 ended at the assay's limit; the forecaster's own chance of this, stated with the estimate: 55%; the middle value sits exactly at the limit.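

In this assay, pyrrolidin-1-yl on this double-bonded ring carbon repeats the pattern seen with piperidin-1-yl: an at least 2.8-fold higher number from compound 2 to compound 4 (0.45 log units; beyond the scatter) and an at least 4.1-fold higher number from compound 1 to compound 4 (0.61 log units; beyond the scatter). Compound 4 joins compound 3 at the limit, so the weaker result is not confined to piperidin-1-yl: the limit of > 16000 nM in this assay, at which 2 of the 4 values shown sit.

The step from compound 3 to compound 4 cannot be read; both values are limits.

From the compounds shown here alone, it remains open whether a morpholin-4-yl ring or an open-chain diethylamino group would also stay at the limit. Also open, going by these compounds, is whether benzylamino, with its aromatic ring set one carbon away from the nitrogen, would read like the anilino compounds.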